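The source may report more compounds than this note shows. Statements on the series, on what has been measured and on what is new or still open speak of the compounds shown alone.

In a functional assay on MCF7 cells (Homo sapiens) for cytotoxicity, read by MTT assay, with a stated time of 48 h (on this read-out higher numbers stand for weaker inhibition and lower numbers for stronger inhibition), compound 2 `COc1cc(C(=O)C2Sc3nnc(-c4cc(OC)c(OC)c(OC)c4)n3NC2c2cccs2)cc(OC)c1OC` gives 71000 nM, the higher of the two numbers recorded so far; compound 1 `COc1cc(-c2nnc3n2NC(c2cccs2)C(C(=O)c2ccc(C)cc2)S3)cc(OC)c1OC` gives 28400 nM. Compound 3 `COc1ccc(C(=O)C2Sc3nnc(-c4cc(OC)c(OC)c(OC)c4)n3NC2c2cccs2)cc1` carries 4-methoxyphenyl in place of 3,4,5-trimethoxyphenyl on a carbonyl carbon. Among the measured compounds shown here, the one measured step that bears on this change is a 2.5-fold higher number from compound 1 to compound 2 (0.40 log units; beyond the scatter), in which 4-methylphenyl gave way to 3,4,5-trimethoxyphenyl at the same carbonyl carbon. Since the new change undoes part of that exchange, a lower number is expected for compound 3, estimated as a step of a 1.9-fold lower number from compound 2 to compound 3 (0.27 log units; within the scatter). Compound 3 is therefore expected to give about 38000 nM, within a range from 16000 nM to 90000 nM.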

Compound 3, half-maximal inhibitory concentration: 49500 nM
For compound 3 the middle estimate is 1.3-fold (0.11 log units) below the measured one, and the stated range covers the measured number.
By their numbers in this assay, from the lowest: compounds 1, 3 and 2 (each within the scatter of the next, the first and the last beyond it).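

At the carbonyl carbon, 4-methoxyphenyl in place of 3,4,5-trimethoxyphenyl gives a 1.4-fold lower number from compound 2 to compound 3 (0.16 log units; within the scatter), so this exchange does not separate the two compounds in this assay. Methoxy in place of methyl on an aromatic carbon gives a 1.7-fold higher number from compound 1 to compound 3 (0.24 log units; within the scatter), so compound 3 is not separated from compound 1 either, and only the pair compound 1 and compound 2 stands apart beyond the scatter. Nothing shown here offers a reason for these numbers. Going by these compounds, what stays open is whether an amine or a carboxylic acid on that aromatic carbon would give a step beyond the scatter.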